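Working notes on the shared core, compound 2 to compound 3

A few compounds are considered here, and "the series" means these few. Any claim that something is new, unique, unknown or untested is made for them only; others in the source may bear on it.

The series rests on the core of compound 1, `CCn1cc(C(=O)C(=O)Nc2ccncc2)c2ccccc21`. In a functional assay on FaDu cells (Homo sapiens) for cytotoxicity, read by MTT assay, with a stated time of 72 h (a lower number here means that less compound is tolerated, a higher number that more compound is tolerated), compound 1 gives > 10000 nM, which is a limit of the assay and not a number. For the measured compounds named here, compound 2, `COC(=O)CCn1cc(C(=O)C(=O)Nc2ccc(OC)nc2)c2ccccc21`, gives 168 nM in this assay and holds the only number in this set. The other value shown sits at the limit of > 10000 nM in this assay, at which 1 of the 2 values shown sits, so compound 2 cannot be placed against any measured neighbour. The next member, compound 3, `COCC(C)(C)n1cc(C(=O)C(=O)Nc2ccc(OC)nc2)c2ccccc21`, differs from compound 2 at one site only: 1-(methoxymethyl)-1-methylethyl in place of 2-(methoxycarbonyl)ethyl on an aromatic nitrogen. Going by the values given here, no step between measured compounds is available from which the size of such a change could be read. The expectation for the step of a 1.8-fold higher number from compound 2 to compound 3 (0.25 log units; within the scatter) is a small shift toward a higher value in this assay, possibly within the usual scatter. Compound 3 is therefore estimated at 300 nM, with a range from 80 nM to 1500 nM.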

Compound 3, concentration lethal to 50% of the cells: 137 nM
Beside the measured number, compound 3's estimate is 2.2-fold (0.34 log units) above it, within the range that was stated.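

In this assay, for the compounds shown here, 1-(methoxymethyl)-1-methylethyl in place of 2-(methoxycarbonyl)ethyl on the aromatic nitrogen gives the first step that can be read: a 1.2-fold lower number from compound 2 to compound 3 (0.09 log units; within the scatter). The two groups have the same count of 6 heavy atoms, yet differ in composition, in hydrogen-bond acceptors (2 leaving, 1 entering) and in the double bond of the leaving group, and these differences leave the read-out within the scatter. Nothing measured here accounts for this result.

Steps to compound 1 cannot be read, since it differs from compound 2 and compound 3 in more than one place. As far as these compounds go, what an amine, a carboxylic acid or a longer chain on this aromatic nitrogen would give remains open.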